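Iodo in place of bromo: a small expected step

A few compounds are considered here, and "the series" means these few. Any claim that something is new, unique, unknown or untested is made for them only; others in the source may bear on it.

In a functional assay on HepG2 cells (Homo sapiens) for inhibition, read by MTT assay (on this read-out higher numbers stand for weaker inhibition and lower numbers for stronger inhibition), compound 1 `COc1cc2ncnc(Nc3ccc(NC(=O)c4ccccc4F)cc3)c2cc1OC` gives 13000 nM. Compound 2 `COc1cc2ncnc(Nc3ccc(NC(=O)c4ccc(Cl)cc4)cc3)c2cc1OC` gives 28000 nM, and compound 3 `COc1cc2ncnc(Nc3ccc(NC(=O)c4ccc(Br)cc4)cc3)c2cc1OC` gives 35000 nM. Compound 3 therefore shares the upper end of these numbers with compound 2, and the two cannot be told apart: a 1.3-fold higher number from compound 2 to compound 3 (0.10 log units; within the scatter). Compound 1 stands clearly lower, as the data show a 2.7-fold higher number from compound 1 to compound 3 (0.43 log units; beyond the scatter).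

The next compound, compound 4 `COc1cc2ncnc(Nc3ccc(NC(=O)c4ccc(I)cc4)cc3)c2cc1OC`, makes one small change to compound 3, with iodo in place of bromo on an aromatic carbon. The group sits para to a large group, the same place that holds the halogen in compound 2 and compound 3.

Going by the values given here, the closest precedent is the exchange of chloro for bromo at that place, which gave a 1.3-fold higher number from compound 2 to compound 3 (0.10 log units; within the scatter). Two other steps are larger, a 2.2-fold higher number from compound 1 to compound 2 (0.33 log units; beyond the scatter) and a 2.7-fold higher number from compound 1 to compound 3 (0.43 log units; beyond the scatter), but they also move the halogen to a different place, so they say less about this change. A single precedent is thin evidence, but no step beyond the scatter is expected here. The expected step is a 1.1-fold higher number from compound 3 to compound 4 (0.04 log units; within the scatter). Compound 4 is estimated at 38000 nM, with an expected range of 20000 nM to 70000 nM.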

Compound 4, half-maximal inhibitory concentration: 40000 nM
Compound 4: the middle estimate sits 1.1-fold (0.02 log units) below what was measured; the measured number falls inside the stated range.
By their numbers in this assay, from the lowest: compound 1; then compounds 2, 3 and 4 (each within the scatter of the next).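

In this assay, three halogens have now been compared at this place, para to a large group, and the newest exchange does not separate them (a 1.1-fold higher number from compound 3 to compound 4 (0.06 log units; within the scatter)), nor does the exchange that links the outer two, iodo in place of chloro (a 1.4-fold higher number from compound 2 to compound 4 (0.15 log units; within the scatter)). Chloro, bromo and iodo therefore cannot be told apart on this read-out, which the single step from chloro to bromo could only hint at. The gap to the 2-fluorophenyl compound stays beyond the scatter (a 3.1-fold higher number from compound 1 to compound 4 (0.49 log units; beyond the scatter)), but that step changes both the halogen and its place on the ring, and no measurement here explains any of these numbers.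

From the compounds shown here alone, whether the lower number of compound 1 belongs to the fluoro group or to its place stays open, and 4-fluorophenyl or 2-iodophenyl on the same carbonyl carbon would separate the two. Going by these compounds, it also stays open whether something other than a halogen at this place, such as an amine or a carboxylic acid, would move the number beyond the scatter.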